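Amino for Nitro on Two Related Cores

The compounds below may be only part of what the source reports. "The series", "measured", "known", "first", "only" and "open" are said of these compounds alone.

Compound 1, `COc1ccc(-n2c(-c3cc(OC)c(OC)c(OC)c3)c(Cl)sc2=O)cc1[N+](=O)[O-]`, was tested in a functional assay on CCRF-CEM cells (Homo sapiens) for antiproliferative activity, with a stated time of 72 h (on this read-out higher numbers stand for weaker inhibition and lower numbers for stronger inhibition), and gave only a limit, > 20000 nM. That reading is the limit of > 20000 nM in this assay, at which 1 of the 3 values shown sits. Compound 2, `COc1ccc(-n2c(-c3cc(OC)c(OC)c(OC)c3)c(Cl)sc2=O)cc1N`, in this assay gives 16200 nM. The change between them is amino in place of nitro on an aromatic carbon, and the resulting step is an at least 1.2-fold lower number from compound 1 to compound 2 (0.09 log units; that floor lies within the scatter); because compound 1 sits at a limit, only a floor for the size of this step is known.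

Compound 3, `COc1ccc(-c2csc(=O)n2-c2cc(OC)c(OC)c(OC)c2)cc1[N+](=O)[O-]`, carries the same nitro group on a different core, and in this assay compound 3 gives 8200 nM. The difference between the core of compound 3 and the core of compound 1 is not broken down here, and compound 2 and compound 3 give numbers within the scatter of one another.

Compound 4, `COc1ccc(-c2csc(=O)n2-c2cc(OC)c(OC)c(OC)c2)cc1N`, has not yet been measured. It differs from compound 3 by amino in place of nitro on an aromatic carbon, the same change that links compound 1 to compound 2, with the same surroundings around the place. On this basis the step from compound 3 to compound 4 is expected to be a 1.5-fold lower number from compound 3 to compound 4 (0.17 log units; within the scatter), a modest lowering in line with the floor seen for the step from compound 1 to compound 2, whose true size is not known beyond that floor. Compound 4 is therefore estimated to give about 5500 nM in this assay, expected to lie between 2200 nM and 14000 nM.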

Compound 4, half-maximal inhibitory concentration: 240 nM
The estimate for compound 4 lay 23-fold (1.36 log units) above the measured number, outside the stated range (below it).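

On the core of compound 3 the change is large: in this assay, amino in place of nitro gives a 34-fold lower number from compound 3 to compound 4 (1.53 log units; beyond the scatter). This shows that the change can have a strong effect in this series, but it does not show whether its size carries over from one core to the other, and the two steps can only be set side by side: the same change on two cores in this assay, an at least 1.2-fold lower number (0.09 log units; that floor lies within the scatter) from compound 1 to compound 2 and a 34-fold lower number (1.53 log units; beyond the scatter) from compound 3 to compound 4; the limit leaves it open whether they differ Compound 1 gives a limit rather than a number, so the step on its core has no upper bound and could be either small or much larger than its floor: the limit of > 20000 nM in this assay, at which 1 of the 4 values shown sits.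

The compounds shown leave open whether the large step belongs to amino itself or would also appear with another group in the same place, such as hydroxyl, methylamino or acetamido. They also leave open which part of the difference between the core of compound 1 and the core of compound 3 bears on the size of the step, as no pair shown differs in only one feature of the core.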